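Tert-butyl in place of 4-methylphenyl on the aromatic nitrogen

The source may report more compounds than this note shows. Statements on the series, on what has been measured and on what is new or still open speak of the compounds shown alone.

Compound 1, `CC(C)(C)c1cc(NC(=O)Nc2ccc(F)cc2)n(-c2ccccc2)n1`, gives 6.5 degrees C in an assay on isolated protein for inhibition of serine/threonine-protein kinase 10 (Homo sapiens), read by thermal shift assay, tested at 10 uM; a higher number here means that the compound stabilises the target more against heat, a lower number that the compound stabilises the target less.
Compound 2, `Cc1ccc(F)cc1NC(=O)Nc1cc(C(C)(C)C)nn1-c1ccccc1`, gives 4.1 degrees C in this assay.
Compound 3, `Cc1ccc(-n2nc(C(C)(C)C)cc2NC(=O)Nc2cc(C(F)(F)F)cc(C(F)(F)F)c2)cc1`, gives -0.5 degrees C in this assay.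

Compound 3 stands lowest of these three numbers, beyond the scatter below compound 2 and further still below compound 1. Compound 4, `CC(C)(C)c1cc(NC(=O)Nc2cc(C(F)(F)F)cc(C(F)(F)F)c2)n(C(C)(C)C)n1`, differs from compound 3 in one place: tert-butyl in place of 4-methylphenyl on an aromatic nitrogen. The only measured step among these compounds, a number 2.4 degrees C lower from compound 1 to compound 2 (beyond the scatter), changes the ring on the amide-type nitrogen, not the group on the aromatic nitrogen, so no measured step speaks directly to this change. Compound 1 carries a plain phenyl on that aromatic nitrogen and sits high, but it also differs from compound 3 on the other side of the urea, so its number cannot be split between the two changes. With nothing to point firmly either way and compound 3 already near zero, a change within the scatter of this assay is expected, a number 1.0 degrees C higher from compound 3 to compound 4 (within the scatter). Compound 4 is therefore estimated at 0.5 degrees C, between -1.5 degrees C and 2.5 degrees C.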

Compound 4, shift of the target's melting temperature: -0.7 degrees C
Estimate against measurement, compound 4: 1.2 degrees C above; the measured number falls inside the stated range.
By their numbers in this assay, from the lowest: compounds 4 and 3 (each within the scatter of the next); then compound 2; then compound 1.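

The swap of 4-methylphenyl for tert-butyl on the aromatic nitrogen gives a number 0.20 degrees C lower from compound 3 to compound 4 (within the scatter) in this assay, so removing the ring and going to the group with fewer heavy atoms leaves no change that can be told from scatter. For the compounds shown here, this is the first measured step at this position, and it shows that, with the rest of the molecule held constant, both groups leave the number close to zero. No measurement shown here offers an explanation for this result.

As far as these compounds go, whether this position would stay as unresponsive alongside the 4-fluorophenyl group of compound 1 remains open. So does the outcome with a quite different group on the aromatic nitrogen, such as a methyl group or a chain ending in an amine.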